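Replacing isopropyl with 4-chlorophenyl in compound 2

The compounds below may be only part of what the source reports. "The series", "measured", "known", "first", "only" and "open" are said of these compounds alone.

In an ADME assay on WI-38 cells (Homo sapiens) for cytotoxicity, read by MTT assay, with a stated time of 72 h (a higher number here means a weaker inhibitor, a lower number a stronger inhibitor), compound 1 (`COc1ccc(NC(=O)CCc2cccc3c2B(O)OC3)cc1`) gives a limit of the assay (> 100000 nM). Compound 2 (`CC(C)c1cccc(NC(=O)CCc2cccc3c2B(O)OC3)c1`) gives 22000 nM as a measured number, and compound 3 (`C#Cc1ccccc1NC(=O)CCc1cccc2c1B(O)OC2`) gives 18000 nM within the scatter of it. Compound 4 (`O=C(CCc1cccc2c1B(O)OC2)Nc1cccc(-c2ccc(Cl)cc2)c1`) differs from compound 2 by having 4-chlorophenyl in place of isopropyl on an aromatic carbon. Among the measured compounds shown here, no measured pair differs in one place only, so the size of this change in this assay is a matter of expectation: a modest move toward a lower number is expected, not far beyond the scatter. An estimated step of a 1.8-fold lower number from compound 2 to compound 4 (0.26 log units; within the scatter) is expected on this basis. For compound 4 the estimated value is 12000 nM (expected range 4000 nM to 40000 nM).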

Compound 4, half-maximal inhibitory concentration: 9800 nM
The estimate for compound 4 lay 1.2-fold (0.09 log units) above the measured number; the measured number falls inside the stated range.
By their numbers in this assay, from the lowest: compounds 4, 3 and 2 (each within the scatter of the next, the first and the last beyond it). At a limit, above all of these: compound 1.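

In this assay the series now has its first step in one place only: a 2.2-fold lower number from compound 2 to compound 4 (0.35 log units; beyond the scatter). It shows that this position, on an aromatic carbon meta to a large group, takes 4-chlorophenyl in place of isopropyl, with its added six-membered aromatic ring, and that the number moves only modestly.

From the compounds shown here alone, whether the step follows from the ring or from the chlorine stays open, as does what an amine or a carboxylic acid would give at this position. Compound 1 also remains a limit of the assay and not a number: the limit of > 100000 nM in this assay, at which 1 of the 4 values shown sits.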